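The source may hold more compounds than are shown below. What is called first, only, known or untested is meant among the compounds shown, and "the series" means these compounds.

Measured so far:
Compound 1 `CCOC(=O)C1=C(Nc2ccc(F)cc2)S/C(=C\c2ccc[nH]2)C1=O` — in a functional assay on MCF7 cells (Homo sapiens) for inhibition, read by MTT assay, with a stated time of 72 h, tested at 10 uM (on this read-out lower numbers stand for less inhibition and higher numbers for more inhibition at the one concentration tested (going by the name of the read-out)), compound 1 gives < 10%, which is a limit of the assay.
Compound 2 `CCOC(=O)C1=C(Nc2cccc(F)c2)S/C(=C\c2ccc[nH]2)C1=O` — in this assay compound 2 gives < 10%, likewise a limit of the assay.
Compound 3 `CCOC(=O)C1=C(Nc2ccc(C(F)(F)F)cc2)S/C(=C\c2ccc[nH]2)C1=O` — in this assay compound 3 gives 19.1%.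

Compound 2 differs from compound 1 by 3-fluorophenyl in place of 4-fluorophenyl on an amine nitrogen; the step is a step that the two limits leave unreadable from compound 1 to compound 2, both values sitting at the limit of < 10% in this assay, at which 2 of the 3 values shown sit. Compound 3 differs from compound 1 by trifluoromethyl in place of fluoro on an aromatic carbon, and the step is a number at least 9.1 percentage points higher from compound 1 to compound 3 (that floor lies within the scatter). Compound 4 `CCOC(=O)C1=C(Nc2cccc(C(F)(F)F)c2)S/C(=C\c2ccc[nH]2)C1=O` is not yet measured. It differs from compound 2 by trifluoromethyl in place of fluoro on an aromatic carbon, the same kind of change as that from compound 1 to compound 3, though here the place is meta to a large group rather than para to a large group. In this assay a step of a number at least 5 percentage points higher from compound 2 to compound 4 (that floor lies within the scatter) is expected for compound 4. That expectation rests on compound 3 and its step of a number at least 9.1 percentage points higher from compound 1 to compound 3 (that floor lies within the scatter). Compound 4 is estimated at 15%, from 5% to 30%.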

Compound 4, a percentage reported as inhibition, at one concentration (the size of the read-out at that concentration, not a potency): 22.9%
Estimate against measurement, compound 4: 7.9 percentage points below; the range from low to high includes it.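

In this assay, trifluoromethyl in place of fluoro gives a number at least 12.9 percentage points higher from compound 2 to compound 4 (beyond the scatter). Carried from one core to the other, the change gives a higher number both times, but this rests on only two pairs, and only the newer step is beyond the scatter: the same change on two cores in this assay, a number at least 9.1 percentage points higher (that floor lies within the scatter) from compound 1 to compound 3 and a number at least 12.9 percentage points higher (beyond the scatter) from compound 2 to compound 4; the limit leaves it open whether they differ The data therefore do not show that the change has the same size on both cores or that it would carry to further cores, and the starting values of both pairs sit at a limit: the limit of < 10% in this assay, at which 2 of the 4 values shown sit.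

Going by these compounds, it remains open whether a nitrile or an amine on the same aromatic carbon would give a higher number than trifluoromethyl. On these data alone, with one concentration tested, the potency of compound 3 and compound 4 also remains open.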